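Two phenyl variations on a shared core against A549 cells

This account rests on a few compounds, and the source may have more. Where it says the series, first, only, none or still open, it means among the compounds named here.

Three compounds built on the same core were tested in a functional assay on A549 cells (Homo sapiens) for cytotoxicity, read by MTT assay, with a stated time of 72 h; on this read-out lower numbers stand for stronger inhibition and higher numbers for weaker inhibition. Compound 1 `COc1cccc(/C=C2\CCC/C(=C\c3ccccc3Br)C2=O)c1OC` reached only the limit of the assay, giving > 20000 nM. Compound 2 `COc1cc(/C=C2\CCC/C(=C\c3cccc(OC)c3OC)C2=O)cc(OC)c1` gave a number, 10200 nM. Compound 3 `COc1ccc(/C=C2\CCC/C(=C\c3ccccc3Cl)C2=O)cc1OC` also reached only the limit, giving > 20000 nM. Compound 3 therefore stands among the weaker members of this small set: its value is a limit, not a number, and the limit of > 20000 nM in this assay, at which 2 of the 3 values shown sit, shows that such limits are the rule here, with only compound 2 giving a measurable value.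

Compound 4 `COc1ccc(/C=C2\CCC/C(=C\c3cccc(O)c3)C2=O)cc1OC` has not yet been measured in this assay. It differs from compound 3 in one place (3-hydroxyphenyl in place of 2-chlorophenyl on a double-bonded chain carbon bound to a double-bonded ring carbon).

Within the data shown here, no step between two measured compounds is available to calibrate this change, so the expectation rests on the three values alone. Compound 2 gave a measurable number, 10200 nM. Compound 3, by contrast, gave only a limit. A change at this position therefore appears able to move the read-out, and a step toward stronger inhibition is expected for an at least 2.2-fold lower number from compound 3 to compound 4 (0.34 log units; beyond the scatter), though it may remain within the scatter. Compound 4 is expected to give 9000 nM, with a range from 2500 nM to 25000 nM.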

Compound 4, half-maximal inhibitory concentration: 4300 nM
For compound 4 the middle estimate is 2.1-fold (0.32 log units) above the measured one, and the stated range covers the measured number.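

In this assay, putting 3-hydroxyphenyl in place of 2-chlorophenyl on a double-bonded chain carbon bound to a double-bonded ring carbon gives an at least 4.6-fold lower number from compound 3 to compound 4 (0.66 log units; beyond the scatter), so a change at this place on the shared core can move the read-out beyond the scatter. The earlier compounds shown here could only hint at this, as no two of them differed in one place. The size of the step remains a bound and not a measured difference, since compound 3 sits at a limit of the assay: the limit of > 20000 nM in this assay, at which 2 of the 4 values shown sit.

The step exchanges a whole ring substituent in one move, so the compounds shown cannot tell whether the lower number comes from losing the chlorine, from gaining the hydroxyl or from where the substituent sits on the phenyl ring. From the compounds shown here alone, how an amine or a carboxylic acid would behave in place of the hydroxyl of the 3-hydroxyphenyl group remains open, as does whether the same change would give a similar step with the other methoxy-bearing phenyl groups on the opposite side of the shared core.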